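Acetyl in place of 3-fluoropropyl: expected cytotoxicity

This account rests on a few compounds, and the source may have more. Where it says the series, first, only, none or still open, it means among the compounds named here.

Three compounds share a core and differ only in the group on a nitrogen on an aromatic ring. In an ADME assay on MT4 cells (Homo sapiens) for cytotoxicity, read by MTT assay, with a stated time of 5 days (a lower number here means that less compound is tolerated, a higher number that more compound is tolerated), compound 1 `CCC(C)N(c1ccnc(Nc2ccc(C#N)cc2)n1)c1c(F)cc(-c2ccc(C#N)cc2)cc1F` gives 217000 nM, compound 2 `N#Cc1ccc(Nc2nccc(N(CC(O)CO)c3c(F)cc(-c4ccc(C#N)cc4)cc3F)n2)cc1` gives 19500 nM, and compound 3 `N#Cc1ccc(Nc2nccc(N(CCCF)c3c(F)cc(-c4ccc(C#N)cc4)cc3F)n2)cc1` gives 241000 nM, which stands at the top of the three but within the scatter of compound 1. Compound 4 `CC(=O)N(c1ccnc(Nc2ccc(C#N)cc2)n1)c1c(F)cc(-c2ccc(C#N)cc2)cc1F` carries acetyl in place of 3-fluoropropyl on a nitrogen on an aromatic ring. Going by the values given here, two steps bear on this: a 1.1-fold higher number from compound 1 to compound 3 (0.05 log units; within the scatter), a plain chain swap, and an 11-fold lower number from compound 1 to compound 2 (1.05 log units; beyond the scatter), where hydroxyl groups entered. Acetyl brings a carbonyl rather than hydroxyls, so only a moderate downward step, a 2.0-fold lower number from compound 3 to compound 4 (0.30 log units; within the scatter), is expected. Compound 4 is therefore estimated at 120000 nM, with a likely range from 35000 nM to 300000 nM.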

Compound 4, half-maximal cytotoxic concentration: > 268000 nM
Compound 4 gave a limit, no number (the forecaster's own chance of this, stated with the estimate: 20%); at least 2.2-fold (0.34 log units) between middle value and limit.
By their numbers in this assay, from the lowest: compound 2; then compounds 1 and 3 (each within the scatter of the next). At a limit, above all of these: compound 4.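

In this assay compound 4 gives > 268000 nM, which is a limit of the assay and not a number. Acetyl therefore brings no measured fall on this nitrogen, unlike the expected downward step: the steps of an at least 1.1-fold higher number from compound 3 to compound 4 (0.04 log units; that floor lies within the scatter) and an at least 1.2-fold higher number from compound 1 to compound 4 (0.09 log units; that floor lies within the scatter) both stay within the scatter at their floors. Of the groups shown, only 2,3-dihydroxypropyl stands clearly apart, with an at least 13-fold higher number from compound 2 to compound 4 (1.13 log units; beyond the scatter).

The limit leaves the true size of these steps open. Going by these compounds, whether an amine or a carboxylic acid on this nitrogen would track acetyl or 2,3-dihydroxypropyl also remains open.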